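Series notes: amide and aryl changes in A549 cytotoxicity

The source may hold more compounds than are shown below. What is called first, only, known or untested is meant among the compounds shown, and "the series" means these compounds.

The shared core bears a pentyl amide in compound 1 `C=CC1=C(C(=O)NCCCCC)C(c2ccc(OC)cc2)OC1`, which in a functional assay on A549 cells (Homo sapiens) for cytotoxicity, read by MTT assay, with a stated time of 24 h (on this read-out higher numbers stand for weaker inhibition and lower numbers for stronger inhibition), gives 36500 nM. Compound 2 `C=CC1=C(C(=O)Nc2ccc(C)cc2)C(c2ccc(F)cc2)OC1` reaches only a limit of this assay, > 100000 nM. Compound 3 `C=CC1=C(C(=O)NCc2ccccc2F)C(c2ccc(F)cc2)OC1` likewise returns only a limit, > 100000 nM. The step that the two limits leave unreadable from compound 2 to compound 3 therefore cannot be read; the series is bounded by the limit of > 100000 nM in this assay, at which 2 of the 3 values shown sit. Compound 4 `C=CC1=C(C(=O)NCCCCC)C(c2ccc(F)cc2)OC1` is the next member, and the change from compound 3 is butyl in place of 2-fluorophenyl on a saturated chain carbon bound to an amide-type nitrogen. No measured step sizes this change, since compound 3 stands at a limit; compound 1, which shares the pentyl amide, at least gives a number. Compound 4 is expected near 50000 nM, within 15000 nM to 150000 nM. The expected step of an at least 2.0-fold lower number from compound 3 to compound 4 (0.30 log units; that floor lies within the scatter) cannot be sized against the limit of compound 3.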

Compound 4, half-maximal inhibitory concentration: > 100000 nM
Compound 4: only a limit was reported; the forecaster's own chance of this, stated with the estimate: 45%; middle value at least 2.0-fold (0.30 log units) from the limit.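

Going by these compounds alone, the one readable step is an at least 2.7-fold higher number from compound 1 to compound 4 (0.43 log units; beyond the scatter); it rests on the limit of compound 4, and it shows that, with the pentyl amide kept, fluoro in place of methoxy on an aromatic carbon matters in this assay. Butyl in place of 2-fluorophenyl on a saturated chain carbon bound to an amide-type nitrogen gives no measurable value, and the steps among compound 2, compound 3 and compound 4 cannot be read. With the fluoro group kept, neither amide type leaves the limit: the limit of > 100000 nM in this assay, at which 3 of the 4 values shown sit.

As far as these compounds go, whether methoxy gives numbers with the 2-fluorobenzyl or 4-methylphenyl amides stays open. So does the effect of an amine or a longer chain on the amide nitrogen.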